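Trading a Hydroxy Group for Hydrogen

The source may hold more compounds than are shown below. What is called first, only, known or untested is meant among the compounds shown, and "the series" means these compounds.

Among the compounds with values here, in a functional assay on FHCC-98 cells (Homo sapiens) for cytotoxicity, read by MTT assay, with a stated time of 24 h (on this read-out lower numbers stand for stronger inhibition and higher numbers for weaker inhibition), compound 2 `COc1cc(O)cc(/C=C/c2ccc(O)c(OC)c2OC)c1` gives 45800 nM, the only actual number so far. Compound 1 `COc1cc(O)cc(/C=C/c2ccc(OC)c(O)c2OC)c1` reaches only a limit of the assay, > 100000 nM. Compound 3 `COc1cc(O)cc(/C=C/c2cccc(OC)c2OC)c1` differs from compound 2 by hydrogen in place of hydroxy on an aromatic carbon, para to a large group. Within the data shown here, no measured step shows what this change does, so only a modest shift towards weaker inhibition in this assay is expected, with the estimated 1.5-fold higher number from compound 2 to compound 3 (0.18 log units; within the scatter). For compound 3, the expected value is 70000 nM, with an estimated range of 25000 nM to 200000 nM.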

Compound 3, half-maximal inhibitory concentration: 80500 nM
Compound 3: the middle estimate sits 1.2-fold (0.06 log units) below what was measured, and the stated range covers the measured number.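

Putting hydrogen in place of the hydroxy group on this aromatic carbon gives a 1.8-fold higher number from compound 2 to compound 3 (0.24 log units; within the scatter), so in this assay the two compounds cannot be told apart, and this hydroxy group is not shown to matter for the read-out. Compound 3 also still gives a real number rather than a limit. Compound 1, by contrast, is only a limit, which shows how little room these weak values leave: the limit of > 100000 nM in this assay, at which 1 of the 3 values shown sits.

From the compounds shown here alone, what an amine or a carboxylic acid on this same carbon would do remains open. So does whether any change here could produce a step beyond the scatter.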